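Cyano for Methyl on the Core of Compound 1

This account rests on a few compounds, and the source may have more. Where it says the series, first, only, none or still open, it means among the compounds named here.

The measured compounds, all tested in an assay on CCRF-CEM cells for antagonist activity at C-C chemokine receptor type 4 (Homo sapiens), read by CellTiter-Glo, with stated times of 30 min and 60 min, in the presence of a further agent that is not named here; on this read-out lower numbers stand for stronger inhibition and higher numbers for weaker inhibition:
- compound 1 `Cc1nn([C@H](C)c2ccc(Cl)cc2Cl)c2nc(C3=CC[C@H](N4CCC[C@H]4CO)[C@H](C)C3)cnc12`: 179 nM
- compound 2 `Cc1nn([C@H](C)c2ccc(Cl)cc2Cl)c2nc(N3CC[C@H](N4CCCCCC4)[C@H](C)C3)cnc12`: 195 nM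
- compound 3 `Cc1nn([C@H](C)c2ccc(Cl)cc2Cl)c2nc(N3CC[C@H](N4CCC[C@H]4CCC(N)=O)[C@H](C)C3)cnc12`: 355 nM

Compound 1 gives the lowest of the three numbers shown, but its gap to compound 2 and its gap to compound 3 both lie within the usual scatter, so the three compounds cannot be told apart on these numbers. Within the data shown here, the only step between two measured compounds that differ in one place is a 1.8-fold higher number from compound 2 to compound 3 (0.26 log units; within the scatter), a swap on a saturated ring carbon.

Compound 4 `C[C@@H]1CC(c2cnc3c(C#N)nn([C@H](C)c4ccc(Cl)cc4Cl)c3n2)=CC[C@@H]1N1CCC[C@H]1CO` has not been measured yet. It differs from compound 1 in one place: cyano in place of methyl on an aromatic carbon. Among the measured compounds shown here, none of the measured compounds carries a change at this aromatic carbon, so no measured step speaks to the effect of this swap. With nothing to lean on, the expected step of a 1.0-fold higher number from compound 1 to compound 4 (0.00 log units; within the scatter) is none beyond the scatter. Compound 4 is therefore estimated at 180 nM, within a range from 60 nM to 550 nM.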

Compound 4, half-maximal inhibitory concentration: 70 nM
The estimate for compound 4 lay 2.6-fold (0.41 log units) above the measured number, and the stated range covers the measured number.
By their numbers in this assay, from the lowest: compound 4; then compounds 1, 2 and 3 (each within the scatter of the next).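

Until now, every compound shown carried methyl at this aromatic carbon, so the position's influence could not be judged. In this assay, cyano in place of methyl gives a 2.6-fold lower number from compound 1 to compound 4 (0.41 log units; beyond the scatter), which shows that the group on this carbon can shift the number and that cyano is accepted here without any loss. No evidence is available on why the number falls.

With only methyl and cyano shown at this carbon, it remains open how other groups there, such as chloro, ethyl or a carboxylic acid, would compare. Going by these compounds, it is also open whether the same swap would give a similar step on compound 2 or compound 3, which differ from compound 1 elsewhere in the structure.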